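The source may hold more compounds than are shown below. What is called first, only, known or untested is meant among the compounds shown, and "the series" means these compounds.

The measured compounds in a functional assay on HT-1080 cells (Homo sapiens) for antiproliferative activity, read by sulforhodamine B assay, with a stated time of 48 h (a higher number here means a weaker inhibitor, a lower number a stronger inhibitor), are:
compound 1, `CCCC(=O)Nc1ccc(S(=O)(=O)Oc2ccccc2C(C)C)cc1`, 950 nM
compound 2, `CCCCCC(=O)Nc1ccc(S(=O)(=O)Oc2ccccc2C(C)C)cc1`, 6300 nM
compound 3, `CC(C)C(=O)Nc1ccc(S(=O)(=O)Oc2ccccc2C(C)C)cc1`, 4900 nM

Compound 3 stands second highest of the three numbers in this assay. Its nearest neighbour is compound 2, with a 1.3-fold lower number from compound 2 to compound 3 (0.11 log units; within the scatter). Its furthest is compound 1, with a 5.2-fold higher number from compound 1 to compound 3 (0.71 log units; beyond the scatter). Compound 4, `CC(C)c1ccccc1OS(=O)(=O)c1ccc(NC(=O)C(C)(C)C)cc1`, differs from compound 3 by methyl in place of hydrogen on a saturated chain carbon bound to a carbonyl carbon and two saturated chain carbons. Within the data shown here, two measured steps bear on this: a 5.2-fold higher number from compound 1 to compound 3 (0.71 log units; beyond the scatter) and a 6.6-fold higher number from compound 1 to compound 2 (0.82 log units; beyond the scatter), both of which raised the number when the group on the carbonyl carbon grew or branched. A further rise beyond the scatter is therefore expected, of modest size. Compound 4 is expected to give 8000 nM, in a range from 3500 nM to 18000 nM. The expected step is a 1.6-fold higher number from compound 3 to compound 4 (0.21 log units; within the scatter).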

Compound 4, half-maximal inhibitory concentration: 11000 nM
For compound 4 the middle estimate is 1.4-fold (0.14 log units) below the measured one; the range from low to high includes it.
By their numbers in this assay, from the lowest: compound 1; then compounds 3, 2 and 4 (each within the scatter of the next, the first and the last beyond it).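

In this assay the methyl that turns isopropyl into tert-butyl on the carbonyl carbon gives a 2.2-fold higher number from compound 3 to compound 4 (0.35 log units; beyond the scatter) and so shows that further branching at this carbon still raises the number. Set against propyl, tert-butyl gives a 12-fold higher number from compound 1 to compound 4 (1.06 log units; beyond the scatter) as the only large step here, while against pentyl it gives a 1.7-fold higher number from compound 2 to compound 4 (0.24 log units; within the scatter) and so stays level with that long chain. Nothing at hand explains these steps. The compounds shown leave open whether ethyl or cyclopropyl on the carbonyl carbon would match propyl, and how a chain ending in an amine would behave there.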